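Changing the alkenyl chain on a weak antiproliferative amide

The source may report more compounds than this note shows. Statements on the series, on what has been measured and on what is new or still open speak of the compounds shown alone.

Values so far in a functional assay on MCF7 cells (Homo sapiens) for antiproliferative activity, read by MTT assay, with a stated time of 72 h; on this read-out lower numbers stand for stronger inhibition and higher numbers for weaker inhibition
Compound 1 `CC(C)/C=C/C(=O)Nc1cccc(Oc2nc(Nc3ccn(C)n3)nc3c2CSCC3)c1` gives > 50000 nM (a limit)
Compound 2 `CC/C=C/C(=O)Nc1cccc(Oc2nc(Nc3ccc(OC)cc3)nc3c2CSCC3)c1` gives 31400 nM
Compound 3 `COc1ccc(Nc2nc3c(c(Oc4cccc(NC(=O)C=C(C)C)c4)n2)CSCC3)cc1` gives > 50000 nM (a limit)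

Compound 3 has no exact number, only the limit > 50000 nM. Its place on the scale is the limit of > 50000 nM in this assay, at which 2 of the 3 values shown sit.

Compound 4 `COc1ccc(Nc2nc3c(c(Oc4cccc(NC(=O)/C=C/C(C)C)c4)n2)CSCC3)cc1` differs from compound 3 in one place, with 3-methylbut-1-en-1-yl in place of 2-methylprop-1-en-1-yl on a carbonyl carbon.

One measured step involves a change at this carbonyl carbon: an at least 1.5-fold higher number from compound 2 to compound 3 (0.20 log units; that floor lies within the scatter). It swaps but-1-en-1-yl for 2-methylprop-1-en-1-yl. Compound 1 also carries 3-methylbut-1-en-1-yl, though it differs elsewhere, and it too reports only a limit, > 50000 nM.

No step beyond the scatter is therefore expected in this assay, and no direction can be favoured. The expected step is small, an at least 1.1-fold lower number from compound 3 to compound 4 (0.04 log units; that floor lies within the scatter). For compound 4 the estimated value is 45000 nM, with an expected range from 22000 nM to 80000 nM.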

Compound 4, half-maximal inhibitory concentration: > 50000 nM
Compound 4 ended at the assay's limit (the forecaster's own chance of this, stated with the estimate: 60%); middle value at least 1.1-fold (0.04 log units) away from the limit.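

In this assay, placing a methyl on the saturated chain carbon of the alkenyl chain gives an at least 1.5-fold higher number from compound 2 to compound 4 (0.20 log units; that floor lies within the scatter), so this extra carbon produces no step beyond the scatter. The steps to compound 4 from compound 3 and from compound 1 cannot be read, as each joins two limits; this position has now taken two branched chains, 2-methylprop-1-en-1-yl and 3-methylbut-1-en-1-yl, and neither gives an exact number with the 4-methoxyphenyl group in place. The scale therefore leaves little room for comparison at this carbonyl carbon: the limit of > 50000 nM in this assay, at which 3 of the 4 values shown sit.

On these data alone, whether any group here can bring the number clearly down remains open. A chain ending in an amine or a carboxylic acid, or a saturated chain lacking the double bond, could help to answer that.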